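Dienone series: chloronitrophenyl to dichlorophenyl exchange

This account rests on a few compounds, and the source may have more. Where it says the series, first, only, none or still open, it means among the compounds named here.

Measured so far:
compound 1 `O=C(/C=C/c1ccc(Oc2ncnc3ccc(Cl)cc23)cc1)/C=C/c1cc([N+](=O)[O-])ccc1Cl` — 2150 nM
compound 2 `O=C(/C=C/c1ccc(Cl)c([N+](=O)[O-])c1)/C=C/c1ccccc1Oc1ncnc2ccc(Cl)cc12` — 5320 nM

Two compounds have been run in a functional assay on MGC-803 cells (Homo sapiens) for inhibition, read by MTT assay, with a stated time of 72 h; a higher number here means a weaker inhibitor, a lower number a stronger inhibitor. Compound 2 gives 5320 nM, the highest of the two numbers recorded. Its nearest neighbour is compound 1, which gives 2150 nM, a lower number by a margin beyond the usual scatter. No single-point change connects compound 1 and compound 2; their structures differ in more than one place, so the gap between them cannot be assigned to any one alteration.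

Compound 3 `O=C(/C=C/c1ccccc1Oc1ncnc2ccc(Cl)cc12)/C=C/c1cccc(Cl)c1Cl` is compound 2 with one change: 2,3-dichlorophenyl in place of 4-chloro-3-nitrophenyl on a double-bonded chain carbon bound to a double-bonded chain carbon. Within the data shown here, no pair of measured compounds isolates this exchange, so there is no measured step to lean on. The expected step is a 1.3-fold lower number from compound 2 to compound 3 (0.12 log units; within the scatter), a small move that is not clearly beyond the scatter in either direction, with a slight lean toward a lower number given that compound 2 sits at 5320 nM, the top of the measured range. For compound 3 the estimate in this assay is 4000 nM, with a range from 1400 nM to 11000 nM.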

Compound 3, half-maximal inhibitory concentration: 5210 nM
Estimate against measurement, compound 3: 1.3-fold (0.11 log units) below, and the stated range covers the measured number.
By their numbers in this assay, from the lowest: compound 1; then compounds 3 and 2 (each within the scatter of the next).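

In this assay, among these compounds, the exchange of 4-chloro-3-nitrophenyl for 2,3-dichlorophenyl on a double-bonded chain carbon bound to a double-bonded chain carbon gives a 1.0-fold lower number from compound 2 to compound 3 (0.01 log units; within the scatter), the first reading of a single change, and it shows no separation between the two groups. The two groups differ in their counts, with 10 heavy atoms and 2 hydrogen-bond acceptors in the leaving group against 8 heavy atoms and 0 hydrogen-bond acceptors in the entering group, yet this one pair shows no readable difference in the assay number. No independent measurement bears on this result, and the data give no explanation for it.

From the compounds shown here alone, compound 1 differs from compound 2 and compound 3 in more than one place, so it remains open whether the same exchange would also read within the scatter on the core of compound 1. Also open, going by these compounds, is whether a group of a different kind at this position, such as a primary amine or a carboxylic acid on the same chain carbon, would move the number beyond the scatter.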